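The source may hold more compounds than are shown below. What is called first, only, known or untested is meant among the compounds shown, and "the series" means these compounds.

Working notes on the series. Compound 2 `Cc1c(-c2ccc(O)c(O)c2)n(CCCCOc2ccccc2)c2ccc(O)cc12` carries the highest number of the three measured in a functional assay on HeLa cells (Homo sapiens) for inhibition, read by trypan blue exclusion, with a stated time of 72 h (a lower number here means a stronger inhibitor of growth, a higher number a weaker inhibitor of growth), where compound 2 gives 10000 nM. Compound 1 `CCCn1c(-c2ccc(O)cc2)c(C)c2cc(O)ccc21` stands nearest, with compound 1 giving 7900 nM in this assay; compound 3 `Cc1c(-c2ccc(O)cc2)n(CCCCOc2ccccc2)c2ccc(O)cc12` stands furthest, compound 3 giving 4000 nM, so that a 2.5-fold lower number from compound 2 to compound 3 (0.40 log units; beyond the scatter).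

Compound 4 `Cc1c(-c2ccc(O)c(O)c2)n(C)c2ccc(O)cc12` differs from compound 2 in one place: hydrogen in place of 3-phenoxypropyl on a saturated chain carbon bound to an aromatic nitrogen. Going by the values given here, the one measured step that touches the same part of the molecule is a 2.0-fold lower number from compound 1 to compound 3 (0.30 log units; within the scatter), and that change runs the opposite way to the present one. Among the compounds with values here, no measured pair shows a methyl on the aromatic nitrogen against a propyl, so that part of the change has no guide here.

Within the data shown here, since the only relevant measured step is within the scatter, the expectation for this assay is a step of no clear size, leaning if anything toward a higher number; the step is estimated as a 1.4-fold higher number from compound 2 to compound 4 (0.15 log units; within the scatter). Compound 4 is therefore expected to give about 14000 nM in this assay, with a likely range from 5000 nM to 40000 nM.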

Compound 4, concentration for 50% growth inhibition: > 20000 nM
Compound 4: a limit, no number; the forecaster's own chance of this, stated with the estimate: 15%; middle value at least 1.4-fold (0.15 log units) from the limit.
By their numbers in this assay, from the lowest: compounds 3, 1 and 2 (each within the scatter of the next, the first and the last beyond it). At a limit, above all of these: compound 4.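

In this assay compound 4 gives > 20000 nM, which is a limit and not a number. The change takes out the whole 3-phenoxypropyl group, six-membered aromatic ring included, and gives an at least 2.0-fold higher number from compound 2 to compound 4 (0.30 log units; that floor lies within the scatter), so this position now shows a step with a direction, whereas the earlier step on the chain, a 2.0-fold lower number from compound 1 to compound 3 (0.30 log units; within the scatter), stayed within the scatter. The floor of the new step also lies within the scatter, and its size is bounded on one side only: the limit of > 20000 nM in this assay, at which 1 of the 4 values shown sits.

The compounds shown do not separate the length of the chain on the aromatic nitrogen from the presence of its phenoxy ring. Also open, going by these compounds, is how a plain hexyl chain, or a chain ending in an amine or a carboxylic acid, would compare at this position.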